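The source may report more compounds than this note shows. Statements on the series, on what has been measured and on what is new or still open speak of the compounds shown alone.

Of the compounds shown here, three have so far been measured in a functional assay on HeLa cells (Homo sapiens) for inhibition, read by MTT assay, with a stated time of 48 h; on this read-out lower numbers stand for stronger inhibition and higher numbers for weaker inhibition. Compound 1 `COc1cc(Cn2cc(COc3cccc(/C=C4/C(=O)Nc5ccccc54)c3)nn2)cc(OC)c1` gives 22000 nM. Compound 2 `O=C1Nc2cc(Cl)ccc2/C1=C\c1cccc(OCc2cn(Cc3ccccc3)nn2)c1` returns only the limit of the assay, > 50000 nM. Compound 3 `O=C1Nc2ccc(F)cc2/C1=C\c1cccc(OCc2cn(Cc3ccccc3)nn2)c1` likewise returns only a limit, > 50000 nM. Compound 3 therefore stands at the edge of what this assay can report, as does compound 2, while compound 1 alone of the three gives a number; two of the three values sit at the limit of > 50000 nM in this assay, at which 2 of the 3 values shown sit. For the measured compounds named here, no pair of the measured compounds differs in a single place, so no measured step is available to guide the next one.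

Compound 4 `O=C1Nc2ccc([N+](=O)[O-])cc2/C1=C\c1cccc(OCc2cn(Cc3ccccc3)nn2)c1` has not yet been measured. It differs from compound 3 by nitro in place of fluoro on an aromatic carbon. Going by the values given here, with compound 3 at a limit and no measured step to lean on, the expectation for compound 4 is a step of a number no higher from compound 3 to compound 4 (the limit leaves the size open), that is, none beyond the scatter, and it is quite possible that compound 4 will again be reported only as a limit. Compound 4 is accordingly estimated at 50000 nM, with a range from 15000 nM to 150000 nM.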

Compound 4, half-maximal inhibitory concentration: > 50000 nM
Compound 4 ended at the assay's limit (the forecaster's own chance of this, stated with the estimate: 60%); the middle value sits exactly at the limit.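

Compound 3 and compound 4 both end at a limit of this assay rather than at a number, so no step can be read from nitro in place of fluoro: the limit of > 50000 nM in this assay, at which 3 of the 4 values shown sit.

The compounds shown leave open whether this exchange changes inhibition at all, and how far compound 3 and compound 4 lie from each other.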